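A few compounds are considered here, and "the series" means these few. Any claim that something is new, unique, unknown or untested is made for them only; others in the source may bear on it.

Compound 1 `COc1ccc(/C=C/C(=O)Nc2cc(-c3ccc(Br)cc3)[nH]n2)cc1` in a functional assay on A549 cells (Homo sapiens) for antiproliferative activity, read by MTT assay, with a stated time of 48 h (on this read-out lower numbers stand for stronger inhibition and higher numbers for weaker inhibition), gives 820 nM. Compound 2 `O=C(/C=C/c1ccc(Br)cc1)Nc1cc(-c2ccc(Br)cc2)[nH]n1` differs from it in one place, where (bromo in place of methoxy on an aromatic carbon); in this assay compound 2 gives 1360 nM, and the step of a 1.7-fold higher number from compound 1 to compound 2 (0.22 log units; within the scatter). Compound 3 `COc1ccc(/C=C/C(=O)Nc2cc(-c3ccc(C)cc3)[nH]n2)cc1` has a different core, and the difference from compound 1 is methyl in place of bromo on an aromatic carbon; in this assay compound 3 gives 1190 nM, a step of a 1.5-fold higher number from compound 1 to compound 3 (0.16 log units; within the scatter). Compound 4 `Cc1ccc(-c2cc(NC(=O)/C=C/c3ccc(Br)cc3)n[nH]2)cc1` is not yet measured. It carries the same change already seen between the first two compounds, now on the core of compound 3: bromo in place of methoxy on an aromatic carbon. The place is the same in both cases, so the change counts as the same one. Because that earlier step a 1.7-fold higher number from compound 1 to compound 2 (0.22 log units; within the scatter), compound 4 is expected to give about 2000 nM, most likely between 1000 nM and 4200 nM. The expected step of a 1.7-fold higher number from compound 3 to compound 4 (0.23 log units; within the scatter) rests on that single earlier step and nothing more.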

Compound 4, half-maximal inhibitory concentration: 1590 nM
Compound 4: the middle estimate sits 1.3-fold (0.10 log units) above what was measured, within the range that was stated.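

In this assay, within the data shown here, the new step for bromo in place of methoxy is a 1.3-fold higher number from compound 3 to compound 4 (0.13 log units; within the scatter), and it agrees with the earlier step on the other core: the same change on two cores in this assay, a 1.7-fold higher number (0.22 log units; within the scatter) from compound 1 to compound 2 and a 1.3-fold higher number (0.13 log units; within the scatter) from compound 3 to compound 4, 1.2-fold (0.09 log units) apart, within the scatter of two such steps The new step for methyl in place of bromo is a 1.2-fold higher number from compound 2 to compound 4 (0.07 log units; within the scatter), and it agrees in the same way: the same change on two cores in this assay, a 1.5-fold higher number (0.16 log units; within the scatter) from compound 1 to compound 3 and a 1.2-fold higher number (0.07 log units; within the scatter) from compound 2 to compound 4, 1.2-fold (0.09 log units) apart, within the scatter of two such steps All of these steps lie within the scatter, so the agreement shows only that neither change moved the number beyond it on either core, not that a real effect of either change carries from one core to another.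

The compounds shown leave open whether an amine, a carboxylic acid or a longer chain at these places would shift the number beyond the scatter. They also leave open whether the agreement would hold on a core carrying such a group.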